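This account rests on a few compounds, and the source may have more. Where it says the series, first, only, none or still open, it means among the compounds named here.

Two compounds share one core and differ only in the aryl group that sits on a saturated chain carbon bound to an oxygen on an aromatic ring. Compound 1 `Cc1ccc(NC(=S)NC(=O)c2ccc(OCc3cccc(C(F)(F)F)c3)cc2)cc1-c1nc2ccccc2[nH]1` carries a 3-(trifluoromethyl)phenyl there, and in a functional assay on MGC-803 cells (Homo sapiens) for inhibition, read by MTT assay, with a stated time of 48 h (a higher number here means a weaker inhibitor, a lower number a stronger inhibitor), compound 1 gives 5210 nM. Compound 2 `Cc1ccc(NC(=S)NC(=O)c2ccc(OCc3ccc(Cl)c(Cl)c3)cc2)cc1-c1nc2ccccc2[nH]1` carries a 3,4-dichlorophenyl instead; in this assay compound 2 gives 6390 nM, the highest of the two numbers shown, and the gap to the nearest is a 1.2-fold higher number from compound 1 to compound 2 (0.09 log units; within the scatter). Compound 3 `Cc1ccc(NC(=S)NC(=O)c2ccc(OCc3ccc(Cl)cc3Cl)cc2)cc1-c1nc2ccccc2[nH]1` has not yet been measured. It differs from compound 2 in one place: 2,4-dichlorophenyl in place of 3,4-dichlorophenyl on a saturated chain carbon bound to an oxygen on an aromatic ring. Among the measured compounds shown here, the only measured step, a 1.2-fold higher number from compound 1 to compound 2 (0.09 log units; within the scatter), altered the same ring at the same place and stayed within the scatter; the present change is more modest, since the two structures hold the same atoms, joined differently. No step beyond the scatter is therefore expected in this assay for compound 3. The estimate for compound 3 in this assay is 6000 nM, within a range from 2500 nM to 14000 nM. This estimate amounts to an expected step of a 1.1-fold lower number from compound 2 to compound 3 (0.03 log units; within the scatter).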

Compound 3, half-maximal inhibitory concentration: 3450 nM
Beside the measured number, compound 3's estimate is 1.7-fold (0.24 log units) above it, and the stated range covers the measured number.
By their numbers in this assay, from the lowest: compounds 3, 1 and 2 (each within the scatter of the next).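

In this assay, among the compounds shown here, the two dichlorophenyl isomers, which hold the same atoms joined differently, are separated by a 1.9-fold lower number from compound 2 to compound 3 (0.27 log units; within the scatter) and so cannot be told apart, even though this is the first comparison of two chlorine placements on this ring. The 2,4-dichlorophenyl and the 3-(trifluoromethyl)phenyl are likewise separated by a 1.5-fold lower number from compound 1 to compound 3 (0.18 log units; within the scatter) and cannot be told apart, so all three aryl groups on a saturated chain carbon bound to an oxygen on an aromatic ring now read as equivalent in this assay, and neither exchanging the substituents nor rearranging the chlorines has produced a step beyond the scatter. No separate measurement accompanies these numbers that could speak to the result.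

The compounds shown leave open whether an aryl group of another kind at this position, such as an unsubstituted phenyl, a 4-methoxyphenyl or a pyridine ring, would give a step beyond the scatter. They also leave open whether a group carrying an amine or a carboxylic acid there would do so on the same shared core.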